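One Side-Chain Change on a Shared Core

The source may hold more compounds than are shown below. What is called first, only, known or untested is meant among the compounds shown, and "the series" means these compounds.

Measured compounds:
- compound 1, `O=C(CN(c1ncnc2c1ncn2C1CCCCO1)C1CC1)N[C@@H](CO)C(=O)OCc1ccccc1`: 27.8%
- compound 2, `O=C(O)CC[C@H](NC(=O)CN(c1nc(Cl)nc2[nH]cnc12)C1CC1)C(=O)O`: 26.8%

Of the compounds shown here, two have been tested in a functional assay on the whole organism (Tail, strain ICR) with Mus musculus as the target, in the tail flick test, with a stated time of 30 min, at a dose of 25 umol/kg by the oral route; on this read-out higher numbers stand for a stronger effect at the one dose given and lower numbers for a weaker effect. Compound 1 gives 27.8%, and compound 2 gives 26.8%. Compound 2 has the lowest of the two numbers, but its nearest neighbour, compound 1, stands only a little higher, and that gap lies within the scatter of repeated measurements, so the two readings cannot be told apart.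

The next compound, compound 3, `CC(C)C[C@H](NC(=O)CN(c1nc(Cl)nc2[nH]cnc12)C1CC1)C(=O)O`, is not yet measured. It differs from compound 2 in one place: isopropyl in place of carboxymethyl on a saturated chain carbon, two bonds along the chain from an amide-type nitrogen and a carbonyl carbon. For the measured compounds named here, the two compounds already measured differ from each other in several places at once, so no single step between measured compounds is available to guide the expectation.

With nothing more to lean on, the change from compound 2 to compound 3 is expected to bring no step beyond the scatter, an estimated a number 1.2 percentage points higher from compound 2 to compound 3 (within the scatter). Compound 3 is therefore expected to give 28%, in a range from 14% to 42%.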

Compound 3, a percentage reported as activity, at one dose (the size of the read-out at that dose, not a potency): 23.4%
Beside the measured number, compound 3's estimate is 4.6 percentage points above it; the measured number falls inside the stated range.
By their numbers in this assay, from the lowest: compounds 3, 2 and 1 (each within the scatter of the next).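

For the compounds shown here, this is the first step in the set that changes only one place. In this assay, putting isopropyl in place of carboxymethyl on a saturated chain carbon, two bonds along the chain from an amide-type nitrogen and a carbonyl carbon, gives a number 3.4 percentage points lower from compound 2 to compound 3 (within the scatter), so the two compounds cannot be told apart. At this position and this one dose, a side chain holding a hydrogen-bond donor and acceptor and one with neither give readings that the scatter cannot separate, so the donor and acceptor of carboxymethyl are not shown to matter for this read-out. Nothing in the data speaks to why this step is so small.

As far as these compounds go, it remains open whether any group at this position can move the read-out beyond the scatter, and an amine, a phenyl ring or a longer chain in the same place would test that. Each reading is also the size of an effect at one dose and not a potency, so whether compound 2 and compound 3 would stay together at other doses is open as well.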